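Anilino to benzylamino: working notes on compound 3

This account rests on a few compounds, and the source may have more. Where it says the series, first, only, none or still open, it means among the compounds named here.

In a functional assay on HepG2 cells (Homo sapiens) for antiproliferative activity, read by CCK-8 assay, with a stated time of 72 h (on this read-out higher numbers stand for weaker inhibition and lower numbers for stronger inhibition), compound 1 (`Cc1ccc(Nc2nc(Cl)nc3c2ncn3Cc2ccc(C(=O)Nc3ccccc3N)cc2)cc1`) gives 860 nM and compound 2 (`Nc1ccccc1NC(=O)c1ccc(Cn2cnc3c(Nc4ccccc4)nc(Cl)nc32)cc1`) gives 4180 nM. Compound 2 thus holds the higher of the two numbers, and the gap between them lies beyond the scatter.

The next compound is compound 3 (`Nc1ccccc1NC(=O)c1ccc(Cn2cnc3c(NCc4ccccc4)nc(Cl)nc32)cc1`). Its difference from compound 2 is benzyl in place of phenyl on a nitrogen on an aromatic ring. This places benzyl in place of phenyl on a nitrogen on an aromatic ring.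

Among the compounds with values here, only one measured step bears on this change, and only indirectly: a 4.9-fold higher number from compound 1 to compound 2 (0.69 log units; beyond the scatter), with hydrogen in place of methyl on an aromatic carbon. This modest step shows that this assay responds to a small change in the anilino group. Within the data shown here, no measured compound carries benzyl, so the data do not fix a direction. A step of comparable size remains possible in either direction, but the central expectation is a slight rise in the number, not clearly beyond the scatter.

The estimated change is a 1.3-fold higher number from compound 2 to compound 3 (0.12 log units; within the scatter). For compound 3 the expected value is 5500 nM, with an estimated range of 1800 nM to 15000 nM.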

Compound 3, half-maximal inhibitory concentration: 7720 nM
Estimate against measurement, compound 3: 1.4-fold (0.15 log units) below, and the stated range covers the measured number.
By their numbers in this assay, from the lowest: compound 1; then compounds 2 and 3 (each within the scatter of the next).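

In this assay, replacing anilino with benzylamino gives a 1.8-fold higher number from compound 2 to compound 3 (0.27 log units; within the scatter), so on the unsubstituted ring this change at the nitrogen on the aromatic ring is not resolved from the scatter, and the numbers of compound 2 and compound 3 cannot be ordered. Within the data shown here, the comparison with the methyl-bearing compound shows a larger separation, a 9.0-fold higher number from compound 1 to compound 3 (0.95 log units; beyond the scatter), and this leaves compound 1 as the strongest of the three on this read-out, with 4-methylphenyl the only group on this nitrogen so far whose number stands apart from the others. No supporting measurement is available to explain either step.

Going by these compounds, whether a methyl group on the benzyl ring, as in 4-methylbenzyl, would lower the number as it does on the anilino ring remains open, so the gain seen with compound 1 cannot yet be said to carry over to the benzylamino series. Also open, on these data alone, is how this assay responds to a longer chain on the same nitrogen, such as phenethyl, or to a saturated ring such as cyclohexyl in place of the aromatic one.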